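A few compounds are considered here, and "the series" means these few. Any claim that something is new, unique, unknown or untested is made for them only; others in the source may bear on it.

Compound 1 `CCNC(=O)[C@H]1O[C@@H](n2cnc3c(NNC(=O)c4ccccc4)ncnc32)[C@H](O)[C@@H]1O` in an assay on CHO cells for displacement of a labelled ligand from adenosine receptor A3 (Homo sapiens) (on this read-out lower numbers stand for stronger inhibition and higher numbers for weaker inhibition), gives > 5000 nM. Compound 2 `CCNC(=O)[C@H]1O[C@@H](n2cnc3c(NNC(=O)c4ccc(Cl)cc4)ncnc32)[C@H](O)[C@@H]1O` gives > 5000 nM. Compound 3 `CCNC(=O)[C@H]1O[C@@H](n2cnc3c(NNC(=O)c4ccc(C)o4)ncnc32)[C@H](O)[C@@H]1O` gives > 5000 nM.

Each of these three values is a limit of this assay, not a number, so compound 1 stands at that limit alongside the others (the limit of > 5000 nM in this assay, at which 3 of the 3 values shown sit). The steps a step that the two limits leave unreadable from compound 1 to compound 2, a step that the two limits leave unreadable from compound 1 to compound 3 and a step that the two limits leave unreadable from compound 2 to compound 3 cannot be sized, since both ends sit at the limit. Compound 4 `CCNC(=O)[C@H]1O[C@@H](n2cnc3c(NNC(=O)c4ccccc4)nc(Cl)nc32)[C@H](O)[C@@H]1O` differs from compound 1 by chloro in place of hydrogen on an aromatic carbon. Going by the values given here, none of the measured steps touches this position of the core, so they give no direction for it. With every neighbour at the limit, compound 4 is expected to show a step that the limit leaves unreadable from compound 1 to compound 4, most likely another limit, estimated at 8000 nM within 2000 nM to 30000 nM.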

Compound 4, inhibition constant: > 5000 nM
Compound 4: no number, only a limit (the forecaster's own chance of this, stated with the estimate: 80%); the middle value does not contradict the limit.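

In this assay, going by these compounds alone, compound 4 gives > 5000 nM, a limit and not a number, so no step from compound 1 to compound 4 can be read. The compounds shown leave open what change, if any, would give a measurable value.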